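The source may hold more compounds than are shown below. What is called first, only, known or untested is meant among the compounds shown, and "the series" means these compounds.

Measured compounds:
- compound 1, `Cc1n[nH]c(C)c1-c1cncc(-c2ccc(C(N)=O)c(OC(C)C)c2)c1`, 33 nM
- compound 2, `CCOc1cc(-c2cccnc2)ccc1C(N)=O`, 2200 nM
- compound 3, `Cc1ncccc1-c1ccc(C(N)=O)cc1`, 170000 nM

In an assay on cells for inhibition of MAP kinase-interacting serine/threonine-protein kinase 1 (Homo sapiens), read by mobility shift assay, with stated times of 10 min and 60 min, in the presence of a further agent that is not named here (a lower number here means a stronger inhibitor, a higher number a weaker inhibitor), compound 1 gives 33 nM, compound 2 gives 2200 nM, and compound 3 gives 170000 nM. Compound 2 stands second highest of the three numbers: compound 1 sits far below it, and compound 3 far above it, both gaps lying beyond the usual scatter of this assay.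

The step under consideration goes from compound 2 to compound 4, `COc1cc(-c2cccnc2)ccc1C(N)=O`, which has not yet been measured. The change is hydrogen in place of methyl on a saturated chain carbon bound to an oxygen on an aromatic ring; cut one bond further out, it reads ethyl to methyl, or ethoxy to methoxy. No step between two measured compounds isolates this change, so there is no direct precedent among the numbers shown.

The expected step of a 1.6-fold higher number from compound 2 to compound 4 (0.20 log units; within the scatter) is small and may stay within the scatter. Compound 4 is estimated at 3500 nM, with a range from 1200 nM to 10000 nM.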

Compound 4, half-maximal inhibitory concentration: 2800 nM
The estimate for compound 4 lay 1.3-fold (0.10 log units) above the measured number; the range from low to high includes it.
By their numbers in this assay, from the lowest: compound 1; then compounds 2 and 4 (each within the scatter of the next); then compound 3.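

In this assay, the change from ethoxy to methoxy amounts to a 1.3-fold higher number from compound 2 to compound 4 (0.10 log units; within the scatter), so the methyl that leaves this saturated chain carbon makes no readable difference. This is the first step among the compounds shown that isolates one change, as the earlier compounds differed from one another in more than one place and could say nothing about this chain alone. Nothing measured here offers an explanation for the result.

From the compounds shown here alone, how far this tolerance extends remains open: a longer chain such as butoxy, or a hydroxyl group in place of the ethoxy, could leave the number level or shift it. Going by these compounds, it is also open whether the same change would read the same way on the core of compound 1.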